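Three chalcone triazoles and an untested difluorophenyl partner

The compounds below may be only part of what the source reports. "The series", "measured", "known", "first", "only" and "open" are said of these compounds alone.

Measured compounds:
compound 1 `COc1cc(O)c(C(=O)/C=C/c2ccc(OC)c(OCc3cn(-c4ccc(F)cc4F)nn3)c2)c(OC)c1`, > 100 ug/mL
compound 2 `COc1cc(O)c(C(=O)/C=C/c2ccc(OC)c(OCc3cn(-c4ccc(Cl)cc4)nn3)c2)c(OC)c1`, > 100 ug/mL
compound 3 `COc1cc(O)c(C(=O)/C=C/c2ccc(OCc3cn(-c4ccc(Cl)cc4)nn3)c(OC)c2)c(OC)c1`, > 100 ug/mL

In an ADME assay on Huh-7 cells (Homo sapiens) for cytotoxicity, read by MTT assay, with a stated time of 72 h (on this read-out higher numbers stand for lower toxicity in this test and lower numbers for higher toxicity in this test), compound 1 returns only a limit, > 100 ug/mL. In this assay compound 2 likewise reaches only a limit, > 100 ug/mL. In this assay compound 3 also sits at a limit, > 100 ug/mL. None of the three therefore carries a number that could be compared with another.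

Compound 1 and compound 2 differ by 2,4-difluorophenyl in place of 4-chlorophenyl on an aromatic nitrogen. The step that the two limits leave unreadable from compound 2 to compound 1 cannot be read, since both ends are limits. Compound 3 shares its atoms with compound 2 but joins them differently; the difference between the two cores is not broken down here. Compound 4 `COc1cc(O)c(C(=O)/C=C/c2ccc(OCc3cn(-c4ccc(F)cc4F)nn3)c(OC)c2)c(OC)c1` stands to compound 3 exactly as compound 1 stands to compound 2: 2,4-difluorophenyl in place of 4-chlorophenyl on an aromatic nitrogen, the same change at the same place.

Going by the values given here, for compound 4 in this assay the expected step is a step that the limit leaves unreadable from compound 3 to compound 4, resting on the fact that every value so far sits at the same limit, (the limit of > 100 ug/mL in this assay, at which 3 of the 3 values shown sit), and that the only measured instance of this change, from compound 2 to compound 1, left both partners at that limit. Compound 4 is thus expected to give 150 ug/mL in this assay, with a plausible range from 60 ug/mL to 400 ug/mL, most likely reported again only as a limit.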

Compound 4, half-maximal cytotoxic concentration: > 100 ug/mL
Compound 4 ended at the assay's limit (the forecaster's own chance of this, stated with the estimate: 85%); the middle value does not contradict the limit.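

In this assay compound 4 gives > 100 ug/mL as a limit and not as a number. No step can be read between compound 3 and compound 4, since both ends are limits: the limit of > 100 ug/mL in this assay, at which 4 of the 4 values shown sit. The compounds shown leave open whether 2,4-difluorophenyl in place of 4-chlorophenyl, or the difference between the two cores, changes the result in this assay at all.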